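Notes on the ethoxycarbonyl analogue of compound 2

A few compounds are considered here, and "the series" means these few. Any claim that something is new, unique, unknown or untested is made for them only; others in the source may bear on it.

Values in a functional assay on SK-OV-3 cells (Homo sapiens) for antiproliferative activity, read by MTT assay, with a stated time of 72 h; on this read-out higher numbers stand for weaker inhibition and lower numbers for stronger inhibition:
compound 1 `O=C(CCc1cccc2c1B(O)OC2)Nc1ccc(Cl)cc1`: 5000 nM
compound 2 `CC(C)(C)OC(=O)Nc1ccc(NC(=O)CCc2cccc3c2B(O)OC3)cc1`: > 100000 nM, a limit of the assay and not a number
compound 3 `CCOC(=O)c1ccc(NC(=O)CCc2cccc3c2B(O)OC3)cc1`: not yet measured

Compound 2 has no exact place on the numbers: it sits at the limit of > 100000 nM in this assay, at which 1 of the 2 values shown sits. Compound 3 carries ethoxycarbonyl in place of (tert-butoxycarbonyl)amino on an aromatic carbon of a six-membered aromatic ring of carbon only, para to a large group: ethoxycarbonyl in place of (tert-butoxycarbonyl)amino on an aromatic carbon. The shared core and the amide chain stay the same.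

For the measured compounds named here, only one measured step bears on this change: an at least 20-fold higher number from compound 1 to compound 2 (1.30 log units; beyond the scatter). That step is large, and it is the step that brought in the group compound 3 gives up. Going by the values given here, with only two measured compounds, this supports a direction more than a size. A large step towards stronger inhibition in this assay is therefore expected. This step starts from compound 2, which stands at a limit of the assay. Compound 3 may not reach the level of compound 1 at 5000 nM. The expected step is an at least 6.6-fold lower number from compound 2 to compound 3 (0.82 log units; beyond the scatter). For compound 3 the estimated value is 15000 nM, with an expected range from 3000 nM to 80000 nM.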

Compound 3, half-maximal inhibitory concentration: > 100000 nM
Compound 3 ended at the assay's limit (the forecaster's own chance of this, stated with the estimate: 20%); at least 6.6-fold (0.82 log units) between middle value and limit.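

In this assay, ethoxycarbonyl in place of chloro on an aromatic carbon gives an at least 20-fold higher number from compound 1 to compound 3 (1.30 log units; beyond the scatter). For the compounds shown here, the loss seen with (tert-butoxycarbonyl)amino is therefore not tied to that one group: ethoxycarbonyl, with fewer heavy atoms and no hydrogen-bond donor, also stands far from compound 1, which is the only one of the three compounds with an exact value. The step from compound 2 to compound 3 cannot be read, and the two groups cannot be ranked against each other: the limit of > 100000 nM in this assay, at which 2 of the 3 values shown sit.

As far as these compounds go, whether an exact value at this position depends on chloro itself stays open, and a fluoro or methyl group, an amine or a carboxylic acid in the same place would test how narrow that requirement is. From the compounds shown here alone, the true strengths of compound 2 and compound 3 also stay open, so the series gives only a direction for these changes and no exact size.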